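Replacing (methylsulfanyl)methyl in compound 1 with 1-carboxy-1-methylethyl

The source may hold more compounds than are shown below. What is called first, only, known or untested is meant among the compounds shown, and "the series" means these compounds.

Compound 1 `COc1ccccc1OCC1SCCN1C(=O)CSC` (21 mg/kg)
Compound 2 `COc1ccccc1OCC1SCCN1C(=O)CNc1cc(Br)cc(Br)c1O` (20 mg/kg)
Compound 3 `CCOC(=O)CC(=O)N1CC[S+]([O-])C1COc1ccccc1OC` (28 mg/kg)

All three compounds were tested in a functional assay on the whole organism (trachea) for inhibition, with Cavia porcellus as the target; on this read-out lower numbers stand for an effect already at smaller amounts and higher numbers for an effect only at larger amounts of compound. There compound 1 gives 21 mg/kg and does not stand apart: its number lies within the usual scatter of the numbers for both compound 2 and compound 3.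

The unmeasured compound 4 `COc1ccccc1OCC1SCCN1C(=O)C(C)(C)C(=O)O` keeps the core of compound 1 and changes one group on a carbonyl carbon, whose other neighbour is an amide-type nitrogen in a ring: 1-carboxy-1-methylethyl in place of (methylsulfanyl)methyl on a carbonyl carbon. In words, 1-carboxy-1-methylethyl stands in place of (methylsulfanyl)methyl.

Among the compounds with values here, no two measured compounds differ in one place only, and the data hold no direct measure of this swap. Still, compound 2 (20 mg/kg) carries a different group on that carbonyl carbon, as does compound 3 (28 mg/kg), which also differs in the core. Both numbers lie within the scatter of the number for compound 1. No change beyond the scatter is therefore expected in this assay, although the incoming group is new to this set and the range must stay wide. The expected step is a 1.2-fold higher number from compound 1 to compound 4 (0.08 log units; within the scatter). For compound 4 the estimated value is 25 mg/kg, with an expected range of 10 mg/kg to 65 mg/kg.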

Compound 4, dose for half-maximal effect: 21 mg/kg
Estimate against measurement, compound 4: 1.2-fold (0.08 log units) above; measured number inside the range.
By their numbers in this assay, from the lowest: compounds 2, 1, 4 and 3 (each within the scatter of the next).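

Within the data shown here, this is the first pair in the set that differs in one place only, so the group on the carbonyl carbon can now be read directly rather than through compounds that also differ elsewhere. In this assay, putting 1-carboxy-1-methylethyl in place of (methylsulfanyl)methyl gives no change at the digits printed from compound 1 to compound 4 (within the scatter), even though the exchange is far from small: 3 heavy atoms with a sulfur leave, 6 heavy atoms with two oxygens enter, and the incoming group brings 1 hydrogen-bond donor where the outgoing group had none. The read-out therefore does not separate these two groups at this place, but nothing at hand explains why.

As far as these compounds go, it remains open whether the carboxylic acid or the two methyl groups of the new group have any part in this result, which a plain 2-methylpropanoyl-type chain without the acid or an ethyl ester of the acid could help to separate. From the compounds shown here alone, it is equally open whether an amine or a longer carbon chain on the same carbonyl carbon would move the number beyond the scatter.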